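A few compounds are considered here, and "the series" means these few. Any claim that something is new, unique, unknown or untested is made for them only; others in the source may bear on it.

Measured in an ADME assay on HepG2 cells (Homo sapiens) for cytotoxicity; a higher number here means that more compound is needed for the effect, a lower number that less compound is needed:
Compound 1 `Cc1ccc(S(=O)(=O)N[C@@H](CC(=O)NC(C)(C)C)C(=O)NCCNC(=O)c2cccc(F)c2)cc1`: > 11000 nM (a limit)
Compound 2 `Cc1ccc(S(=O)(=O)N[C@@H](CC(=O)NC(C)(C)C)C(=O)NCCNC(=O)c2cccc(C#N)c2)cc1`: > 11000 nM (a limit)

Compound 2 gives > 11000 nM, which is a limit of the assay and not a number, so it has only a limit to stand on. Compound 1 gives > 11000 nM, which is likewise a limit.

Compound 3 `Cc1ccc(S(=O)(=O)N[C@@H](CC(=O)NC(C)(C)C)C(=O)NCCNC(=O)c2cc(C)ccc2F)cc1` has 2-fluoro-5-methylphenyl in place of 3-cyanophenyl on a carbonyl carbon. The core it shares with compound 2 stays the same.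

For the measured compounds named here, the one measured step that bears on this change is a step that the two limits leave unreadable from compound 1 to compound 2, where cyano replaces fluoro on an aromatic carbon. Its size cannot be read. The record so far comes down to the limit of > 11000 nM in this assay, at which 2 of the 2 values shown sit. Going by the values given here, no step of definite size or direction is therefore expected in this assay, and compound 3 is expected to be reported as a limit as well.

The expected step is a step that the limit leaves unreadable from compound 2 to compound 3, an estimate that carries little weight while no number exists on either side. For compound 3 the estimated value is 20000 nM, with an expected range from 8000 nM to 50000 nM.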

Compound 3, half-maximal effective concentration: > 11000 nM
Compound 3: only a limit was reported; the forecaster's own chance of this, stated with the estimate: 85%; the middle value lies beyond the limit too.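

In this assay compound 3 gives > 11000 nM, which is a limit of the assay and not a number. For the compounds shown here, compound 1 and compound 2 also stand only on limits, so no step among the three compounds can be read. The compounds shown leave open whether 3-fluorophenyl, 3-cyanophenyl and 2-fluoro-5-methylphenyl differ at all in this assay.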